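Bis-furan amidines: methoxy for chloro on the terminal ring

The compounds below may be only part of what the source reports. "The series", "measured", "known", "first", "only" and "open" are said of these compounds alone.

Compound 1 `N=C(N)c1ccc(-c2ccc(-c3cncc4ccccc34)s2)s1`, compound 2 `N=C(N)c1ccc(-c2ccc(-c3ccc(F)cc3)o2)o1` and compound 3 `N=C(N)c1ccc(-c2ccc(-c3ccc(Cl)cc3)o2)o1` have been run in a functional assay on PC-3 cells (Homo sapiens) for inhibition, read by sulforhodamine B assay, with a stated time of 48 h; on this read-out higher numbers stand for weaker inhibition of growth and lower numbers for stronger inhibition of growth. Compound 3 gives 1810 nM. Among the measured compounds shown here, compound 1 gives 1560 nM and compound 2 gives 1220 nM; all three numbers lie inside the usual scatter of one another, so no compound stands apart. For the measured compounds named here, the one single-point step so far, a 1.5-fold higher number from compound 2 to compound 3 (0.17 log units; within the scatter), concerns the same aromatic carbon as the change now considered. Compound 4 `COc1ccc(-c2ccc(-c3ccc(C(=N)N)o3)o2)cc1` carries the change (methoxy in place of chloro on an aromatic carbon). Going by the values given here, no measured step exchanges a halogen for methoxy at this position, so the expectation rests on the step from compound 2 to compound 3 alone, which stayed within the scatter. The step from compound 3 to compound 4 in this assay is therefore expected to be a 1.1-fold lower number from compound 3 to compound 4 (0.03 log units; within the scatter), with no direction called beyond the scatter. Compound 4 is estimated at 1700 nM, with a range from 700 nM to 4200 nM.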

Compound 4, concentration for 50% growth inhibition: 1880 nM
Estimate against measurement, compound 4: 1.1-fold (0.04 log units) below, and the stated range covers the measured number.
By their numbers in this assay, from the lowest: compounds 2, 1, 3 and 4 (each within the scatter of the next).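

In this assay, among the compounds shown here, methoxy is the only group at this place that is not a halogen, and the exchange for chloro, with 2 heavy atoms and 1 hydrogen-bond acceptor entering, gives a 1.0-fold higher number from compound 3 to compound 4 (0.02 log units; within the scatter) on an aromatic carbon para to a large group. Against fluoro the same carbon gives a 1.5-fold higher number from compound 2 to compound 4 (0.19 log units; within the scatter), so fluoro, chloro and methoxy all stay within the scatter of one another in compounds 2, 3 and 4, and none of these three goes against that. No measurement offers an account of this result.

From the compounds shown here alone, whether an amine, a carboxylic acid or a chain longer than methoxy on this carbon would stay within the scatter remains open. Also open, going by these compounds, is whether methoxy would give the same picture on the core of compound 1.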